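This account rests on a few compounds, and the source may have more. Where it says the series, first, only, none or still open, it means among the compounds named here.

Measured compounds:
compound 1 `COc1cc(-c2c(C)nn(-c3nc(-c4ccc(Cl)c(Cl)c4)c(SC(C)C)s3)c2C(=O)O)cc(C(F)(F)F)c1` with 1380 nM
compound 2 `Cc1nn(-c2nc(-c3ccc(Cl)c(Cl)c3)c(SC(C)C)s2)c(C(=O)O)c1-c1ccc(Cl)cc1` with 2500 nM
compound 3 `Cc1nn(-c2nc(-c3ccc(Cl)c(Cl)c3)c(SC(C)C)s2)c(C(=O)O)c1-c1cnccn1` with 14000 nM

All three share one core and differ only in the group on the aromatic carbon of the pyrazole ring. In a functional assay on BJAB cells (Homo sapiens) for antiproliferative activity, with a stated time of 4 days (a lower number here means that less compound is needed, a higher number that more compound is needed for the effect), compound 3 stands at the highest number of the three: a 5.6-fold higher number from compound 2 to compound 3 (0.75 log units; beyond the scatter) and a 10-fold higher number from compound 1 to compound 3 (1.01 log units; beyond the scatter), both beyond the scatter, while a 1.8-fold higher number from compound 1 to compound 2 (0.26 log units; within the scatter) lies within it.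

Compound 4 `COc1cc(C#N)cc(-c2c(C)nn(-c3nc(-c4ccc(Cl)c(Cl)c4)c(SC(C)C)s3)c2C(=O)O)c1` carries the change (3-cyano-5-methoxyphenyl in place of pyrazin-2-yl on an aromatic carbon). The two steps that bear on it are the ones toward compound 3, which show the pyrazinyl group needing far more compound than either phenyl group. A phenyl group carrying a methoxy group, as in compound 1, returns to the lower range. For compound 4 a drop is therefore expected, a 7.0-fold lower number from compound 3 to compound 4 (0.85 log units; beyond the scatter), giving an estimate of 2000 nM with a range from 800 nM to 5000 nM.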

Compound 4, half-maximal effective concentration: 5200 nM
Beside the measured number, compound 4's estimate is 2.6-fold (0.41 log units) below it; measured number outside the range, above it.
By their numbers in this assay, from the lowest: compounds 1 and 2 (each within the scatter of the next); then compound 4; then compound 3.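

In this assay, a carbon-only ring at this position regains only part of the ground lost with pyrazin-2-yl (a 2.7-fold lower number from compound 3 to compound 4 (0.43 log units; beyond the scatter)), and it does not reach the 4-chlorophenyl level (a 2.1-fold higher number from compound 2 to compound 4 (0.32 log units; beyond the scatter)). The substituent on the ring also counts: with the methoxy group kept, cyano and trifluoromethyl do not give the same result (a 3.8-fold higher number from compound 1 to compound 4 (0.58 log units; beyond the scatter)). No measurement shown explains these differences. Still open, as far as these compounds go, is where an unsubstituted phenyl ring, or a phenyl ring carrying an amine, would fall.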